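Antiproliferative series: bromo in place of ethyl

This account rests on a few compounds, and the source may have more. Where it says the series, first, only, none or still open, it means among the compounds named here.

Measured so far:
- compound 1 `N#CC1=C(N)Oc2c(c3nc4ccccc4nc3c3ccccc23)C12C(=O)N(Cc1cnnn1-c1cccc(Cl)c1)c1ccccc12`: in an ADME assay on HUVEC cells (Homo sapiens) for antiproliferative activity, read by MTT assay, with a stated time of 48 h (a lower number here means a stronger inhibitor, a higher number a weaker inhibitor), compound 1 gives > 50000 nM, which is a limit of the assay and not a number.
- compound 2 `Cc1ccc(Cl)cc1-n1nncc1CN1C(=O)C2(C(C#N)=C(N)Oc3c2c2nc4ccccc4nc2c2ccccc32)c2ccccc21`: compound 2 gives > 50000 nM, again a limit of the assay.
- compound 3 `CCc1ccccc1-n1nncc1CN1C(=O)C2(C(C#N)=C(N)Oc3c(N)cc4nc5ccccc5nc4c32)c2ccccc21`: compound 3 gives > 50000 nM, also a limit of the assay.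

Compound 3 therefore stands nowhere distinct on the numbers shown: all three measured compounds sit at the same point, namely (the limit of > 50000 nM in this assay, at which 3 of the 3 values shown sit), and no ranking among them can be read. For the measured compounds named here, the single step between two measured compounds that differ in one place, a step that the two limits leave unreadable from compound 1 to compound 2, is unreadable in size because both of its ends are limits.

Compound 4 `N#CC1=C(N)Oc2c(N)cc3nc4ccccc4nc3c2C12C(=O)N(Cc1cnnn1-c1ccccc1Br)c1ccccc12` differs from compound 3 by bromo in place of ethyl on an aromatic carbon. Going by the values given here, no measured step bears on this change; the only step available is itself unreadable, so the data give no direction and no size for it. The expectation for compound 4 rests only on the fact that every measured compound in this assay sits at the limit, and compound 4 is expected to do the same. Compound 4 is estimated at 80000 nM, within a range of 20000 nM to 400000 nM. The step that the limit leaves unreadable from compound 3 to compound 4 that this estimate means is expected to be none beyond the scatter.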

Compound 4, half-maximal inhibitory concentration: 34200 nM
For compound 4 the middle estimate is 2.3-fold (0.37 log units) above the measured one, within the range that was stated.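

For the compounds shown here, compound 4 is the first compound to give a number and not a limit in this assay, with 34200 nM. Going by these compounds alone, the change from 2-ethylphenyl to 2-bromophenyl, on an aromatic carbon ortho to a large group, therefore gives the first step with a readable floor, an at least 1.4-fold lower number from compound 3 to compound 4 (0.16 log units; that floor lies within the scatter), which shows that this position can carry a group with a value inside the assay's range, though the floor alone does not establish a change beyond the scatter. Going by these compounds, only that floor can be given and the true size of the step stays unknown, because the other values shown are limits: the limit of > 50000 nM in this assay, at which 3 of the 4 values shown sit.

The compounds shown leave open what other groups at this place, such as methoxy, an amine or a carboxylic acid, would give, and whether any of them would lower the number further. On these data alone, it also remains open whether bromo at this place would give a number on the core of compound 1, which so far reads only at the limit.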